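One fluoro added to compound 3

The source may hold more compounds than are shown below. What is called first, only, known or untested is meant among the compounds shown, and "the series" means these compounds.

Measured so far in an ADME assay on the whole organism (Rattus norvegicus, strain Sprague-Dawley) for pharmacokinetics, read by LC-MS; on this read-out higher numbers stand for wider distribution into tissues and lower numbers for narrower distribution
Compound 1 `N#Cc1ccc(O[C@H]2CN(S(=O)(=O)c3ccc(Cl)cc3Cl)C[C@@]2(O)CO)cc1` gives 2.4 L/kg
Compound 2 `N#Cc1ccc(S(=O)(=O)[C@H]2CN(S(=O)(=O)c3ccc(Cl)cc3Cl)C[C@@H]2O)cc1` gives 1.1 L/kg
Compound 3 `N#Cc1ccc(S(=O)(=O)[C@H]2CN(S(=O)(=O)c3ccc(Cl)cc3Cl)C[C@@]2(O)CO)cc1` gives 2.3 L/kg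

Compound 3 (2.3 L/kg) sits within the scatter of compound 1 (2.4 L/kg), while compound 2 (1.1 L/kg) gives a lower number, beyond the scatter of compound 3.

Compound 4 `N#Cc1ccc(S(=O)(=O)[C@H]2CN(S(=O)(=O)c3ccc(Cl)cc3Cl)C[C@@]2(O)CO)cc1F` has not yet been measured. It differs from compound 3 by fluoro in place of hydrogen on an aromatic carbon in one place: fluoro in place of hydrogen on an aromatic carbon, ortho to a cyano group, which turns 4-cyanophenyl into 4-cyano-3-fluorophenyl.

No measured pair among these compounds shows this change, so the expectation rests on compound 3 (2.3 L/kg) alone. In this assay the expected step of a 1.0-fold lower number from compound 3 to compound 4 (0.02 log units; within the scatter) is none beyond the scatter, in either direction. The estimate for compound 4 is 2.2 L/kg (expected range 1.2 L/kg to 4 L/kg).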

Compound 4, volume of distribution at steady state: 1.2 L/kg
Compound 4: the middle estimate sits 1.8-fold (0.26 log units) above what was measured, within the range that was stated.
By their numbers in this assay, from the lowest: compounds 2, 4, 3 and 1 (each within the scatter of the next, the first and the last beyond it).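

The step of a 1.9-fold lower number from compound 3 to compound 4 (0.28 log units; within the scatter) in this assay is the only reading of this change among these compounds, and it shows that fluoro in place of hydrogen, ortho to a cyano group, does not move the read-out beyond the scatter on this parent. For the compounds shown here, the earlier compounds offered no pair that differed in one place, so this is the first direct view of how sensitive this position is, and it rests on one pair, 4-cyanophenyl to 4-cyano-3-fluorophenyl. Nothing measured here bears on why the step has this size. From the compounds shown here alone, whether a chloro, a methoxy or an amine in the same place would give a step beyond the scatter remains open. So does whether the same fluoro would give a similar step on compound 1.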